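A Carbonyl Substituent Swap on Compound 3

A few compounds are considered here, and "the series" means these few. Any claim that something is new, unique, unknown or untested is made for them only; others in the source may bear on it.

Of the compounds shown here, three have so far been measured in a functional assay on PC-3 cells (Homo sapiens) for cytotoxicity, read by MTT assay, with a stated time of 48 h; on this read-out lower numbers stand for stronger inhibition and higher numbers for weaker inhibition. Compound 1 `CCC(=O)N1N=C(C)CC1c1cc(Br)ccc1O` gives 37800 nM. Compound 2 `CC1=NN(C(=O)CN2CCC(c3ccccc3)CC2)C(c2ccccc2O)C1` gives 20400 nM. Compound 3 `Cc1ccc(C(=O)N2N=C(c3cc4ccccc4oc3=O)CC2c2ccccc2)cc1` gives 13200 nM, the lowest number of the three. Its nearest neighbour is compound 2, whose number sits higher by an amount that stays within the scatter, so the two cannot be told apart; compound 1 is the furthest, with a number beyond the scatter above that of compound 3.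

Compound 4 `O=C(CNC1CCCCC1)N1N=C(c2cc3ccccc3oc2=O)CC1c1ccccc1` has not yet been measured. It differs from compound 3 in a single place: (cyclohexylamino)methyl in place of 4-methylphenyl on a carbonyl carbon. Among the compounds with values here, no pair of measured compounds differs by this change, so there is no measured step to lean on. Compound 2 is built on a different core from compound 3, so only the two values themselves can be set side by side, and compound 2 with 20400 nM lies within the scatter of compound 3.

With nothing pointing firmly either way, compound 4 is expected to give a number close to that of compound 3, a step of a 1.1-fold higher number from compound 3 to compound 4 (0.06 log units; within the scatter) that stays within the scatter. Compound 4 is estimated at 15000 nM, with a range from 5000 nM to 45000 nM.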

Compound 4, half-maximal inhibitory concentration: 48500 nM
Compound 4: the middle estimate sits 3.2-fold (0.51 log units) below what was measured; measured number above the stated range.
By their numbers in this assay, from the lowest: compounds 3, 2, 1 and 4 (each within the scatter of the next, the first and the last beyond it).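

Within the data shown here, this is the first measured change to the group on the carbonyl carbon whose other neighbour is the amide-type nitrogen in a ring, and it shows that this place is not indifferent to what it carries. In this assay, replacing 4-methylphenyl with (cyclohexylamino)methyl gives a 3.7-fold higher number from compound 3 to compound 4 (0.57 log units; beyond the scatter), a modest step that still lies beyond the scatter and points to weaker inhibition with the entering group. The swap alters several things at once, exchanging an aromatic carbon ring for a non-aromatic one and adding a nitrogen with a hydrogen-bond donor and acceptor, and nothing measured here indicates which of these differences matters.

The compounds shown leave open whether the nitrogen or the loss of the aromatic ring goes with the higher number: a cyclohexylmethyl group would keep the non-aromatic ring without the nitrogen, while a (phenylamino)methyl group would keep the nitrogen with an aromatic ring. As far as these compounds go, it also remains open whether another aromatic group at this place, such as 4-methoxyphenyl or 4-chlorophenyl, would give a number different from that of compound 3.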